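Swapping a propyl for a phenyl on the side chain

The source may report more compounds than this note shows. Statements on the series, on what has been measured and on what is new or still open speak of the compounds shown alone.

Of the compounds shown here, three sharing one core have been measured in a functional assay on the whole organism (arterial blood) with Rattus norvegicus as the target; a lower number here means that less compound is needed, a higher number that more compound is needed for the effect. Compound 1 `COC(=O)NC(CC(=O)N1CCC(Cn2c(C)nc3cnccc32)CC1)c1ccccc1` gives 0.035 mg/kg in this assay. Compound 2 `CCCC(CC(=O)N1CCC(Cn2c(C)nc3cnccc32)CC1)c1ccccc1` carries a propyl where compound 1 carries a (methoxycarbonyl)amino group; in this assay compound 2 gives 0.0079 mg/kg. Compound 3 `Cc1nc2cnccc2n1CC1CCN(C(=O)CC(C)(C)c2ccccc2)CC1` gives 0.012 mg/kg in this assay. Compound 2 therefore has the lowest number of the three: the step of a 4.4-fold lower number from compound 1 to compound 2 (0.65 log units; beyond the scatter) is clear, whereas the step of a 1.5-fold higher number from compound 2 to compound 3 (0.18 log units; within the scatter) is not.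

Compound 4 `Cc1nc2cnccc2n1CC1CCN(C(=O)CC(c2ccccc2)c2ccccc2)CC1` is not yet measured. It differs from compound 2 in a single place: phenyl in place of propyl on a saturated chain carbon bound to an aromatic carbon and a saturated chain carbon.

Going by the values given here, two measured steps bear on this change. The step of a 4.4-fold lower number from compound 1 to compound 2 (0.65 log units; beyond the scatter) shows that the side group on this chain carbon can move the number markedly when a group with donors and acceptors is replaced by plain carbon. The step of a 1.5-fold higher number from compound 2 to compound 3 (0.18 log units; within the scatter) shows that rearranging the carbon-only groups around that position did little. Since phenyl, like propyl, brings no donor or acceptor, the second step seems the closer guide, so the expected step of a 1.1-fold higher number from compound 2 to compound 4 (0.06 log units; within the scatter) is small. Compound 4 is estimated to give 0.009 mg/kg in this assay, with a likely range from 0.003 mg/kg to 0.027 mg/kg.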

Compound 4, dose for 50% inhibition: 0.0086 mg/kg
Estimate against measurement, compound 4: 1.0-fold (0.02 log units) above; low and high end bracket the measured number.
By their numbers in this assay, from the lowest: compounds 2, 4 and 3 (each within the scatter of the next); then compound 1.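

In this assay, the step of a 1.1-fold higher number from compound 2 to compound 4 (0.04 log units; within the scatter) shows that phenyl, a six-membered aromatic ring of carbon only, can stand in place of the open propyl chain on this saturated chain carbon without the number leaving the usual scatter. The step of a 4.1-fold lower number from compound 1 to compound 4 (0.61 log units; beyond the scatter) is beyond the scatter, so compound 4 repeats what compound 2 showed alone: here two different groups without hydrogen-bond donors or acceptors, one a chain and one a ring, both give a clearly lower number than the (methoxycarbonyl)amino group of compound 1. No measurement at hand explains why propyl and phenyl give numbers within the scatter of each other, or why both differ from that group of compound 1.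

The compounds shown leave open whether the number would hold with a saturated ring such as cyclohexyl or a longer chain such as hexyl on this carbon. They also leave open how a free amine or a carboxylic acid at the same place would compare with the (methoxycarbonyl)amino group, and what a fluorine on the phenyl ring would do.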